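Amine-ring swap: pyridine to chloropyrimidine

A few compounds are considered here, and "the series" means these few. Any claim that something is new, unique, unknown or untested is made for them only; others in the source may bear on it.

Compound 1 `C[C@@H](Cn1ccc(-c2ccc(C#N)c(Cl)c2)n1)Nc1cccnc1` gives 430 nM in a functional assay on LNCaP cells (Homo sapiens) for antiproliferative activity, read by CCK-8 assay, with a stated time of 6 days; a lower number here means a stronger inhibitor, a higher number a weaker inhibitor. Compound 2 `C[C@@H](Cn1ccc(-c2ccc(C#N)c(Cl)c2)n1)Nc1ccncc1` gives 2560 nM, the higher of the two numbers measured, after the step of a 6.0-fold higher number from compound 1 to compound 2 (0.77 log units; beyond the scatter). Compound 3 `C[C@@H](Cn1ccc(-c2ccc(C#N)c(Cl)c2)n1)Nc1nccc(Cl)n1` follows from compound 2 through (4-chloropyrimidin-2-yl in place of pyridin-4-yl on an amine nitrogen). Among the compounds with values here, only that single step bears on this change, and it concerns the position of a ring nitrogen rather than a second nitrogen or a chlorine, so it guides weakly. A modest downward step seems the most likely expectation, a 2.6-fold lower number from compound 2 to compound 3 (0.41 log units; beyond the scatter), and compound 3 is expected to give 1000 nM in this assay, within 200 nM to 5000 nM.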

Compound 3, half-maximal inhibitory concentration: 1400 nM
For compound 3 the middle estimate is 1.4-fold (0.15 log units) below the measured one; measured number inside the range.
By their numbers in this assay, from the lowest: compound 1; then compounds 3 and 2 (each within the scatter of the next).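

Placing 4-chloropyrimidin-2-yl on the amine nitrogen in this assay gives a 1.8-fold lower number from compound 2 to compound 3 (0.26 log units; within the scatter), so this ring and pyridin-4-yl cannot be told apart here, even though the new ring adds a chlorine and a second ring nitrogen. Pyridin-3-yl remains the better of the three, with a 3.3-fold higher number from compound 1 to compound 3 (0.51 log units; beyond the scatter). No measurement at hand explains these numbers.

On these data alone, whether the chlorine or the second ring nitrogen matters more on its own stays open. So does what a methoxy group or an amine in place of that chlorine would give.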